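Swapping 4-nitrophenyl for pyridin-2-yl in a small series

The source may report more compounds than this note shows. Statements on the series, on what has been measured and on what is new or still open speak of the compounds shown alone.

Compound 1 `Nc1nc(N)c2cc(CSC(=S)N3CCN(c4ccccc4)CC3)ccc2n1`: 2970 nM
Compound 2 `CC(=O)c1ccc(N2CCN(C(=S)SCc3ccc4nc(N)nc(N)c4c3)CC2)cc1`: 2550 nM
Compound 3 `Nc1nc(N)c2cc(CSC(=S)N3CCN(c4ccc([N+](=O)[O-])cc4)CC3)ccc2n1`: 1910 nM

All three compounds were tested in a functional assay on A549 cells (Homo sapiens) for antiproliferative activity, read by MTT assay, with a stated time of 72 h; on this read-out lower numbers stand for stronger inhibition and higher numbers for weaker inhibition. There, compound 3 gives 1910 nM, a value that cannot be separated from the other two: a 1.3-fold lower number from compound 2 to compound 3 (0.13 log units; within the scatter) and a 1.6-fold lower number from compound 1 to compound 3 (0.19 log units; within the scatter).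

The next compound, compound 4 `Nc1nc(N)c2cc(CSC(=S)N3CCN(c4ccccn4)CC3)ccc2n1`, differs from compound 3 in one place, with pyridin-2-yl in place of 4-nitrophenyl on an amine nitrogen in a ring. The measured steps that bear on this change are the three made on the same aromatic ring: a 1.2-fold lower number from compound 1 to compound 2 (0.07 log units; within the scatter), a 1.6-fold lower number from compound 1 to compound 3 (0.19 log units; within the scatter) and a 1.3-fold lower number from compound 2 to compound 3 (0.13 log units; within the scatter). Each of them is small and lies within the scatter. Within the data shown here, none of them, however, replaces the whole aromatic ring, and no measured compound carries pyridin-2-yl, so they offer only indirect guidance.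

On this basis, no step beyond the scatter is expected in this assay, and no firm direction can be assigned. The expected change is a 1.3-fold higher number from compound 3 to compound 4 (0.10 log units; within the scatter). For compound 4 the estimated value is 2400 nM, with an expected range from 1000 nM to 5000 nM.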

Compound 4, half-maximal inhibitory concentration: 3960 nM
Beside the measured number, compound 4's estimate is 1.7-fold (0.22 log units) below it; measured number inside the range.
By their numbers in this assay, from the lowest: compounds 3, 2, 1 and 4 (each within the scatter of the next, the first and the last beyond it).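

In this assay, among these compounds, replacing the whole aromatic ring on the amine nitrogen in a ring gives the only step that lies beyond the scatter: a 2.1-fold higher number from compound 3 to compound 4 (0.32 log units; beyond the scatter). This modest step holds for one pair alone, since the same pyridin-2-yl group stays within the scatter of the other two groups at this position, with a 1.6-fold higher number from compound 2 to compound 4 (0.19 log units; within the scatter) and a 1.3-fold higher number from compound 1 to compound 4 (0.12 log units; within the scatter), so the position tolerates all of these replacements without a step beyond the scatter except where 4-nitrophenyl leaves. Nothing available here accounts for the step from 4-nitrophenyl to pyridin-2-yl.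

The compounds shown leave open whether the step belongs to the loss of the nitro group, to the entry of the ring nitrogen, or to both, and compound 4 alone cannot separate the two parts of this change. They also leave open how this amine nitrogen responds to groups of another kind, such as a pyrimidine ring, a benzyl group or a simple methyl, any of which would show whether an aromatic ring attached directly to this nitrogen is needed at all.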